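Amide swap on a shared core: cyclobutyl to methylthiazolyl

A few compounds are considered here, and "the series" means these few. Any claim that something is new, unique, unknown or untested is made for them only; others in the source may bear on it.

Measured compounds:
compound 1, `CCCCNc1nc(N)nc2c1CN(C(=O)CC)CC2`, 0.4 uM
compound 2, `CCCCNc1nc(N)nc2c1CN(C(=O)C1CCC1)CC2`, 0.4 uM

Both measured compounds share one core and differ only in the group attached to the carbonyl carbon of the ring amide. In an assay on HEK293 cells for agonist activity at Toll-like receptor 8 (Homo sapiens), read by a luciferase reporter, with a stated time of 6 h (on this read-out higher numbers stand for an effect only at larger amounts of compound and lower numbers for an effect already at smaller amounts), compound 1 gives 0.4 uM, and compound 2 gives 0.4 uM. Among the measured compounds shown here, the single measured step, no change at the digits printed from compound 1 to compound 2 (within the scatter), therefore shows that enlarging a small chain to a small ring on that carbonyl carbon left the read-out where it was. Compound 2 stands level with compound 1; neither can be called the more active.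

The unmeasured compound 3, `CCCCNc1nc(N)nc2c1CN(C(=O)c1scnc1C)CC2`, carries a different group at the same place: 4-methyl-1,3-thiazol-5-yl in place of cyclobutyl on a carbonyl carbon. For the measured compounds named here, the only step that bears on this position is the one from compound 1 to compound 2, which was within the scatter, so the carbonyl substituent has so far looked tolerant of change. An aromatic ring with two hetero atoms is, however, a larger departure than anything measured, so the expectation is uncertain. The step of no change at the digits printed from compound 2 to compound 3 (within the scatter) is expected to stay within the scatter. Compound 3 is estimated at 0.4 uM in this assay, with a likely range from 0.1 uM to 1.6 uM.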

Compound 3, minimum effective concentration: 5.6 uM
Beside the measured number, compound 3's estimate is 14-fold (1.15 log units) below it, and the stated range ends below it.
By their numbers in this assay, from the lowest: compounds 1 and 2 (each within the scatter of the next); then compound 3.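

In this assay the group on the carbonyl carbon turns out to matter after all: 4-methyl-1,3-thiazol-5-yl in place of cyclobutyl gives a 14-fold higher number from compound 2 to compound 3 (1.15 log units; beyond the scatter) and, in place of ethyl, gives a 14-fold higher number from compound 1 to compound 3 (1.15 log units; beyond the scatter) as well, so compound 3 needs a clearly larger amount of compound to show an effect. The level reading of ethyl and cyclobutyl therefore marks a tolerance that holds for those two groups and does not reach this five-membered aromatic ring. The swap changes several things at once, bringing in an aromatic ring, a nitrogen, a sulfur and a methyl group, and nothing available shows which of these lies behind the higher number.

Still open, as far as these compounds go, is whether a plain phenyl ring on the carbonyl carbon would read like the 4-methyl-1,3-thiazol-5-yl group or like cyclobutyl, which would separate the effect of an aromatic ring from that of its nitrogen and sulfur. Also open, from the compounds shown here alone, is how a longer carbon chain or an amine at this place would read.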